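Replacing the pyridinium head group of compound 3

The source may hold more compounds than are shown below. What is called first, only, known or untested is meant among the compounds shown, and "the series" means these compounds.

The series shares one core, varied at the head of a long chain on the aromatic ring. Compound 1 `Cc1cc(OCCCCCCC[n+]2ccccc2)ccc1-n1cc(C(=O)Nc2cc(F)cc(F)c2)c(=O)c2ccc(N(C)C)nc21` is reported in an assay on LX2 cells for inhibition of COL1A1 promoter (Homo sapiens), read by a luciferase reporter, with a stated time of 24 h, tested at 20 uM (on this read-out higher numbers stand for a stronger effect at the one concentration tested and lower numbers for a weaker effect), as "not active" (no number reported). Compound 2 `Cc1ccc(-n2cc(C(=O)Nc3cc(F)cc(F)c3)c(=O)c3ccc(N(C)C)nc32)cc1OCCCCCCC[n+]1ccccc1` gives 39.7% in this assay. Compound 3 `CN(C)c1ccc2c(=O)c(C(=O)Nc3cc(F)cc(F)c3)cn(-c3ccc(Cl)c(OCCCCCCC[n+]4ccccc4)c3)c2n1` is reported in this assay as "not active" (no number reported), so no single number is available for it; it is one of two entries in the set without a number, and only compound 2 carries a measured value.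

Compound 4 `CN(C)c1ccc2c(=O)c(C(=O)Nc3cc(F)cc(F)c3)cn(-c3ccc(Cl)c(OCCCCCCC[N+](C)(C)C4CCCCC4)c3)c2n1` differs from compound 3 in one place: a group of 9 heavy atoms (8 carbon, 1 nitrogen; one six-membered non-aromatic ring of carbon only) in place of a group of 6 heavy atoms (5 carbon, 1 nitrogen; one six-membered aromatic ring with 1 hetero atom), on a saturated chain carbon, seven bonds along the chain from an oxygen on an aromatic ring. For the measured compounds named here, no measured pair in the set shows such a step, so its size is unknown. With compound 3 reported without a number, the expectation for compound 4 is a weak read-out in this assay, with no step beyond the usual scatter foreseen in either direction. Compound 4 is therefore estimated to give 15% in this assay, within a range from 0% to 40%.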

Compound 4, a percentage reported as inhibition, at one concentration (the size of the read-out at that concentration, not a potency): 37.6%
Estimate against measurement, compound 4: 22.6 percentage points below; the measured number falls inside the stated range.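

For the compounds shown here, compound 3 carries no number in this assay while compound 4 gives 37.6%, and no step between them can be read. The compounds shown leave open how the head group alone bears on this read-out. Nothing measured here offers an explanation for the result.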